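A few compounds are considered here, and "the series" means these few. Any claim that something is new, unique, unknown or untested is made for them only; others in the source may bear on it.

Three analogues of the shared core have been run in an ADME assay on EA.hy 926 cells (Homo sapiens) for inhibition, read by sulforhodamine B assay, with a stated time of 72 h; a higher number here means a weaker inhibitor, a lower number a stronger inhibitor. Compound 1 `CCCNC(=C\C(=O)/C=C/c1ccc(O)c(OC)c1)/C=C/c1ccc(O)c(OC)c1` is the propylamino member. In this assay compound 1 gives > 25000 nM, which is a limit of the assay and not a number. Compound 2 `CCC(C)NC(=C\C(=O)/C=C/c1ccc(OC(C)=O)c(OC)c1)/C=C/c1ccc(OC(C)=O)c(OC)c1` carries a (sec-butyl)amino group; in this assay compound 2 gives > 25000 nM, again a limit. Compound 3 `COc1cc(/C=C/C(=O)/C=C(/C=C/c2ccc(OC(C)=O)c(OC)c2)NC2CCCCC2)ccc1OC(C)=O` has cyclohexyl in place of sec-butyl on the amine nitrogen; in this assay compound 3 gives > 25000 nM, also a limit. Among the compounds with values here, the single comparable step, a step that the two limits leave unreadable from compound 2 to compound 3, is therefore unreadable, and compound 1 stands with the other two at the limit of > 25000 nM in this assay, at which 3 of the 3 values shown sit. Compound 4 `CCC(C)NC(=C\C(=O)/C=C/c1ccc(O)c(OC)c1)/C=C/c1ccc(O)c(OC)c1` differs from compound 1 by methyl in place of hydrogen on a saturated chain carbon bound to an amine nitrogen and a saturated chain carbon. Within the data shown here, no measured step reads on this change. Compound 4 is expected to stay at the limit, with an expected step that the limit leaves unreadable from compound 1 to compound 4. The estimate for compound 4 is 40000 nM, ranging from 20000 nM to 120000 nM.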

Compound 4, half-maximal inhibitory concentration: > 25000 nM
Compound 4: no number, only a limit; the forecaster's own chance of this, stated with the estimate: 85%; the middle value is on the limit's open side.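

No new step can be read between compound 1 and compound 4, as each gives a limit and not a number: the limit of > 25000 nM in this assay, at which 4 of the 4 values shown sit.

The compounds shown leave open which change to the shared core, if any, would give a readable number in this assay.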